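The source may report more compounds than this note shows. Statements on the series, on what has been measured and on what is new or still open speak of the compounds shown alone.

Working notes on the series built on the shared core: compound 1 `c1ccc(-c2ccncn2)c(OCC2=NCCN2)c1`, compound 2 `c1coc(-c2ccccc2OCC2=NCCN2)c1` and compound 3 `c1c[nH]c(-c2ccccc2OCC2=NCCN2)c1`. In a functional assay for activation of Alpha-1D adrenergic receptor (Homo sapiens), read by calcium flux (a higher number here means that more compound is needed for the effect, a lower number that less compound is needed), compound 1 gives only a limit of the assay, < 100000 nM. Compound 2 likewise returns only a limit in this assay, < 100000 nM. Among the measured compounds shown here, compound 3 is the single member with a number in this assay, 6.31 nM. On the values shown compound 3 stands alone, the entries for compound 1 and compound 2 being limits of the assay (the limit of < 100000 nM in this assay, at which 2 of the 3 values shown sit). The three steps among the measured compounds, a step that the two limits leave unreadable from compound 1 to compound 2, a step that the limit leaves unreadable from compound 1 to compound 3 and a step that the limit leaves unreadable from compound 2 to compound 3, cannot be sized, since two of the three values sit at a limit (the limit of < 100000 nM in this assay, at which 2 of the 3 values shown sit).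

Compound 4 `c1ccc(-c2cc[nH]n2)c(OCC2=NCCN2)c1` is not yet measured. It differs from compound 3 by 1H-pyrazol-3-yl in place of 1H-pyrrol-2-yl on an aromatic carbon. For the measured compounds named here, none of the measured steps has a readable size, so nothing here shows how far an exchange of one five-membered ring for another moves this assay. Taking compound 3 at 6.31 nM as the only anchor, a modest loss is expected, a 3.2-fold higher number from compound 3 to compound 4 (0.50 log units; beyond the scatter). Compound 4 is therefore estimated at 20 nM in this assay, within 3 nM to 150 nM.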

Compound 4, half-maximal effective concentration: < 100000 nM
Compound 4 gave a limit, no number (the forecaster's own chance of this, stated with the estimate: 10%); the middle value is on the limit's open side.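

Compound 4 gives only a limit in this assay, < 100000 nM, and none of its steps to compound 1, compound 2 or compound 3 can be read: the limit of < 100000 nM in this assay, at which 3 of the 4 values shown sit.

The compounds shown leave open the size of any exchange among the pyrimidin-4-yl, furan-2-yl, 1H-pyrrol-2-yl and 1H-pyrazol-3-yl groups.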